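This account rests on a few compounds, and the source may have more. Where it says the series, first, only, none or still open, it means among the compounds named here.

Measured compounds:
- compound 1, `c1ccc(-c2ccc(-c3ccc(-c4nc5ccccc5[nH]4)cc3)cc2)cc1`: 100000 nM
- compound 2, `COc1ccc(-c2ccc(-c3ccc(-c4nc5ccccc5[nH]4)cc3)cc2)cc1`: 38100 nM
- compound 3, `COc1ccc(-c2ccc(-c3ccc(-c4nc5c(O)cccc5[nH]4)cc3)cc2)cc1OC`: 1110 nM

Of the compounds shown here, three have been tested in a functional assay on Gurav cells (Homo sapiens) for inhibition, read by sulforhodamine B assay; on this read-out lower numbers stand for stronger inhibition of growth and higher numbers for weaker inhibition of growth. Compound 1 gives 100000 nM. Compound 2 gives 38100 nM, and the step between them, a 2.6-fold lower number from compound 1 to compound 2 (0.42 log units; beyond the scatter), comes from a single change, (methoxy in place of hydrogen on an aromatic carbon). Compound 3 gives 1110 nM and stands lowest of the three; it is built on a different core than compound 1, and the difference between the two cores is not broken down here.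

Compound 4, `COc1cc(-c2ccc(-c3ccc(-c4nc5c(O)cccc5[nH]4)cc3)cc2)cc(OC)c1OC`, has not been measured in this assay. It differs from compound 3 by methoxy in place of hydrogen on an aromatic carbon. This is the same kind of change that turns compound 1 into compound 2, but the surroundings are not the same: in compound 2 the incoming methoxy sits para to a large group, whereas in compound 4 it sits ortho to a methoxy group, meta to a large group and meta to a methoxy group.

Within the data shown here, the only measured precedent, the step from compound 1 to compound 2, was a modest lowering, and this is the only basis available. Among the measured compounds shown here, for compound 4 the step is expected to be a 1.5-fold lower number from compound 3 to compound 4 (0.17 log units; within the scatter), smaller than the one from compound 1 to compound 2 because the surroundings differ and because compound 3 gives 1110 nM, a number already far below the others. Compound 4 is therefore estimated at 750 nM, between 250 nM and 2500 nM.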

Compound 4, concentration for 50% growth inhibition: 170 nM
For compound 4 the middle estimate is 4.4-fold (0.64 log units) above the measured one; measured number below the stated range.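

In this assay, methoxy in place of hydrogen on an aromatic carbon gives a 6.5-fold lower number from compound 3 to compound 4 (0.81 log units; beyond the scatter), so the lowering seen on the core of compound 1 appears again on the core of compound 3. Set side by side, the two steps run the same way and their sizes cannot be told apart: the same change on two cores in this assay, a 2.6-fold lower number (0.42 log units; beyond the scatter) from compound 1 to compound 2 and a 6.5-fold lower number (0.81 log units; beyond the scatter) from compound 3 to compound 4, 2.5-fold (0.40 log units) apart, within the scatter of two such steps

This shows that the change carried over in direction between these two cores, but it rests on a single pair for each core and does not show that the step has a fixed size or that it would hold on a further core, and in compound 4 the methoxy enters ortho to a methoxy group, so the effect of the core is not separated from that of the surroundings.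

The compounds shown leave open whether a longer chain such as ethoxy, or an amine, placed where the new methoxy of compound 4 sits, would give a lower or a higher number. They also leave open what happens on this read-out when the hydroxyl group on the core of compound 4 gives way to an amine or a carboxylic acid.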